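Extending the amino chain of compound 1

The source may report more compounds than this note shows. Statements on the series, on what has been measured and on what is new or still open speak of the compounds shown alone.

- compound 1 `NCCCNc1c(C(=O)NCc2ccc(F)cc2)nc(Br)c2cccnc12` with "not determined" (no result reported) as its result
- compound 2 `NCCCNc1c(C(=O)NCc2ccc(F)cc2)ncc2cccnc12` with > 10000 nM as its result, a limit

In a functional assay on SK-BR-3 cells (Homo sapiens) for cytotoxicity, read by MTT assay, with a stated time of 72 h (on this read-out lower numbers stand for stronger inhibition and higher numbers for weaker inhibition), compound 1 stands without a number, its entry reading "not determined" (no result reported) and nothing more. Compound 2 gives > 10000 nM as its result, and that is a limit, not a number. Among the measured compounds shown here, no measured step is therefore available as a guide. Compound 3 `NCCCCCCNc1c(C(=O)NCc2ccc(F)cc2)nc(Br)c2cccnc12` is still unmeasured. The structural change is 3-aminopropyl in place of amino on a saturated chain carbon, three bonds along the chain from a nitrogen on an aromatic ring in which 3-aminopropyl stands in place of amino on a saturated chain carbon, three bonds along the chain from a nitrogen on an aromatic ring. With no starting number, the expectation in this assay is only a moderate step toward stronger inhibition, a little beyond the usual scatter, and a result reported only as a limit remains quite possible. For compound 3 the estimated value is 5000 nM with 800 nM to 20000 nM as the expected range.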

Compound 3, half-maximal inhibitory concentration: 3000 nM
Beside the measured number, compound 3's estimate is 1.7-fold (0.22 log units) above it; the measured number falls inside the stated range.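

Compound 1 has no number in this assay, so no step can be read from it to compound 3, which gives 3000 nM. The compounds shown leave open how the change from the 3-aminopropyl chain to the 6-aminohexyl chain alters cytotoxicity on its own.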